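This account rests on a few compounds, and the source may have more. Where it says the series, first, only, none or still open, it means among the compounds named here.

Measured so far:
- compound 1 `COCCn1c(-c2ccccc2Cl)nc2c(N3CCN(C(C)=O)CC3)nc(C)nc21`: 95%
- compound 2 `COCCn1c(-c2ccccc2Cl)nc2c(N3CCN4C(=O)CCC4C3)nc(C)nc21`: 91%
- compound 3 `Cc1nc(N2CCN(C)CC2)c2nc(-c3cccc(C(F)(F)F)c3)n(C3CCOCC3)c2n1`: 28%

In an ADME assay (liver) for metabolic stability, with Liver microsome (Rattus norvegicus) as the target, read by LC-MS, using microsomes, with a stated time of 30 min, tested at 4 uM (a lower number here means that less of the compound is left, a higher number that more of the compound is left), compound 3 stands lowest of the three at 28%, well apart from the other two compounds. The next compound, compound 4 `COc1cccc(-c2nc3c(N4CCN(C)CC4)nc(C)nc3n2C2CCOCC2)c1`, keeps everything in compound 3 except one group: methoxy in place of trifluoromethyl on an aromatic carbon, meta to a large group (methoxy in place of trifluoromethyl on an aromatic carbon).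

Only one measured step links two of these compounds: a number 4 percentage points lower from compound 1 to compound 2 (within the scatter). That step changes a different part of the molecule, so it gives only weak guidance here. Going by the values given here, no measured pair shows this exchange of groups, and the data therefore favour no direction. Compound 3, at 28%, is the closest relative, so the expectation stays near it. The expected change is a number 2 percentage points lower from compound 3 to compound 4 (within the scatter), with no shift beyond the scatter. For compound 4 the estimated value is 26%, with an expected range from 8% to 50%.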

Compound 4, percent of the compound remaining: 30%
For compound 4 the middle estimate is 4 percentage points below the measured one; measured number inside the range.
By their numbers in this assay, from the lowest: compounds 3 and 4 (each within the scatter of the next); then compounds 2 and 1 (each within the scatter of the next).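

In this assay, the change from 3-(trifluoromethyl)phenyl to 3-methoxyphenyl gives a number 2 percentage points higher from compound 3 to compound 4 (within the scatter). This is the only pair shown that changes this position, and it indicates that, with the rest of compound 3 held fixed, exchanging trifluoromethyl for methoxy on this aromatic carbon does not move the read-out beyond the usual scatter. Nothing measured here offers an explanation for this result.

From the compounds shown here alone, only these two groups can be compared at this position, so it remains open whether another group there, such as a nitrile, an amine or a carboxylic acid, would shift the number beyond the scatter. It is also unknown whether the same exchange would give a similarly small step with the other groups found in compound 1.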